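Replacing the benzyl group of compound 2: clearance notes

This account rests on a few compounds, and the source may have more. Where it says the series, first, only, none or still open, it means among the compounds named here.

- compound 1 `Cc1nc(C)c([C@H](OC(C)(C)C)C(=O)O)c(N2CCC(C)(C)CC2)c1-c1ccc2c(c1)CCN(Cc1cccc(F)c1C)C2`: 4 mL/min/kg
- compound 2 `Cc1nc(C)c([C@H](OC(C)(C)C)C(=O)O)c(N2CCC(C)(C)CC2)c1-c1ccc2c(c1)CCN(Cc1ccc(F)cc1F)C2`: 20.1 mL/min/kg

In an ADME assay on the whole organism (Rattus norvegicus, strain Sprague-Dawley) for pharmacokinetics, read by LC-MS, at a dose of 1 mg/kg by the intravenous route (on this read-out higher numbers stand for fast clearance and lower numbers for slow clearance), compound 2 stands highest of the two at 20.1 mL/min/kg. Compound 3 `Cc1nc(C)c([C@H](OC(C)(C)C)C(=O)O)c(N2CCC(C)(C)CC2)c1-c1ccc2c(c1)CCN(c1ncnc3c1cnn3C)C2` differs from it on an amine nitrogen in a ring: a group of 10 heavy atoms (6 carbon, 4 nitrogen; one five-membered aromatic ring with 2 hetero atoms, one six-membered aromatic ring with 2 hetero atoms) in place of a group of 9 heavy atoms (7 carbon, 2 fluorine; one six-membered aromatic ring of carbon only), on an amine nitrogen in a ring. For the measured compounds named here, one measured step bears on this, a 5.0-fold higher number from compound 1 to compound 2 (0.70 log units; beyond the scatter), modest but beyond the scatter, and made by a change on the same nitrogen. Going by the values given here, no measured compound carries the entering group, so the direction is uncertain. Compound 1, at 4 mL/min/kg, shows that lower numbers occur in the series. The expected change, of similar or smaller size, is a 2.2-fold lower number from compound 2 to compound 3 (0.35 log units; beyond the scatter). The estimate for compound 3 is 9 mL/min/kg, with an expected range of 3 mL/min/kg to 25 mL/min/kg.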

Compound 3, clearance: 3.6 mL/min/kg
Beside the measured number, compound 3's estimate is 2.5-fold (0.40 log units) above it, and the stated range covers the measured number.
By their numbers in this assay, from the lowest: compounds 3 and 1 (each within the scatter of the next); then compound 2.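

In this assay a low number on the amine nitrogen in a ring does not depend on a benzyl group, as the entering group, with two aromatic rings and 6 carbon and 4 nitrogen atoms, gives a 5.6-fold lower number from compound 2 to compound 3 (0.75 log units; beyond the scatter) and so recovers the low end of the series. The comparison with the 3-fluoro-2-methylbenzyl group shows a 1.1-fold lower number from compound 1 to compound 3 (0.05 log units; within the scatter) and so no separation between the two groups. Nothing measured here accounts for either step.

Open, as far as these compounds go, is whether a single pyrimidine ring on this nitrogen keeps the number low, and whether an unsubstituted benzyl group falls with compound 2 or with compound 1.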